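Chloro removal from compound 2 in this series

A few compounds are considered here, and "the series" means these few. Any claim that something is new, unique, unknown or untested is made for them only; others in the source may bear on it.

Compound 2 `Clc1ccc(Nc2ccc(N3CC4CC(C3)N4)cn2)cc1` is the reference point. In an assay on cell membranes for displacement of a labelled ligand from Neuronal acetylcholine receptor; alpha4/beta2 (Rattus norvegicus) (a higher number here means a weaker inhibitor, a lower number a stronger inhibitor), compound 2 gives 2.49 nM, the lowest of the three numbers at hand. For the measured compounds named here, compound 1 `Clc1ccc(Nc2ccc(N3CC4CC(C3)N4)nn2)cc1Cl` gives 516 nM in this assay, and compound 3 `CN(c1ccccc1)c1ccc(N2CC3CC(C2)N3)nn1` gives 1430 nM; both gaps to compound 2 lie beyond the scatter, but each of these pairs differs in more than one place, so no single step is isolated. Compound 4 `c1ccc(Nc2ccc(N3CC4CC(C3)N4)cn2)cc1` differs from compound 2 only by hydrogen in place of chloro on an aromatic carbon. Going by the values given here, no measured pair shows this change. A modest weakening is expected, with the step of a 3.2-fold higher number from compound 2 to compound 4 (0.51 log units; beyond the scatter) judged small. Compound 4 is estimated at 8 nM in this assay, within a range of 2.5 nM to 30 nM.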

Compound 4, inhibition constant: 2.66 nM
Beside the measured number, compound 4's estimate is 3.0-fold (0.48 log units) above it, and the stated range covers the measured number.
By their numbers in this assay, from the lowest: compounds 2 and 4 (each within the scatter of the next); then compound 1; then compound 3.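

In this assay, for the compounds shown here, the change from 4-chlorophenyl to phenyl gives a 1.1-fold higher number from compound 2 to compound 4 (0.03 log units; within the scatter), the only step at hand that isolates one place. On this aromatic carbon, para to a large group, chloro is therefore not required for the low number of compound 2 in this assay, and hydrogen serves equally well. Nothing on hand explains this result.

Open, on these data alone, is whether larger or different groups here, such as methoxy, an amine or a carboxylic acid, would stay within the scatter of compound 4. Also open, as far as these compounds go, is whether the same change would read alike on the core of compound 1.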